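Ethoxy for Phenyl on a Sulfonyl-Substituted Acylguanidine Core

The source may hold more compounds than are shown below. What is called first, only, known or untested is meant among the compounds shown, and "the series" means these compounds.

Measured so far in a functional assay for inhibition of sodium/hydrogen exchanger (Oryctolagus cuniculus); on this read-out higher numbers stand for weaker inhibition and lower numbers for stronger inhibition:
compound 1, `Cc1c(C(=O)N=C(N)N)cc(S(C)(=O)=O)c(Cl)c1Cl`: 29 nM
compound 2, `Cc1cc(-c2ccccc2)c(S(C)(=O)=O)cc1C(=O)N=C(N)N`: 19 nM

Among the two numbers in this assay, compound 2 holds the lower one, with compound 1 close by; the gap between compound 1 and compound 2 is within the scatter, so neither can be called the stronger inhibitor on this evidence. Compound 3, `CCOc1cc(C)c(C(=O)N=C(N)N)cc1S(C)(=O)=O`, is not yet measured in this assay. It differs from compound 2 at one place: ethoxy in place of phenyl on an aromatic carbon. Among the measured compounds shown here, no step between measured compounds informs this particular change, and the two measured compounds each carry different groups at that place while giving similar numbers. Compound 3 is therefore expected to land in the same neighbourhood, with a step of a 2.1-fold higher number from compound 2 to compound 3 (0.32 log units; beyond the scatter) toward a somewhat higher number, not clearly beyond the scatter. Compound 3 is estimated at 40 nM, between 12 nM and 130 nM.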

Compound 3, half-maximal inhibitory concentration: 19 nM
Compound 3: middle estimate off by 2.1-fold (0.32 log units), on the high side, and the stated range covers the measured number.
By their numbers in this assay, from the lowest: compounds 2, 3 and 1 (each within the scatter of the next).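

In this assay, among the compounds shown here, the exchange of phenyl for ethoxy on the aromatic carbon ortho to the methylsulfonyl group gives no change at the digits printed from compound 2 to compound 3 (within the scatter) and provides the first comparison at this position. An aromatic ring of 6 heavy atoms and an open group of 3 heavy atoms with 1 hydrogen-bond acceptor thus give matching numbers, so for these two compounds the ring is not needed at this carbon. Nothing available explains why the two groups match.

Going by these compounds, it remains open what an amine such as dimethylamino, a carboxylic acid or a longer chain such as butoxy would do on this same carbon. Also open, on these data alone, is whether plain hydrogen there would keep the number in this range.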